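One Side-Chain Swap on Compound 2

The source may hold more compounds than are shown below. What is called first, only, known or untested is meant among the compounds shown, and "the series" means these compounds.

In a functional assay on HepG2 cells (Homo sapiens) for cytotoxicity, read by sulforhodamine B assay, with a stated time of 48 h (on this read-out higher numbers stand for weaker inhibition of growth and lower numbers for stronger inhibition of growth), compound 1 `Cc1nn(-c2ccccc2)c(Oc2ccc(-c3nc4cc([N+](=O)[O-])ccc4[nH]3)cc2)c1/C=N/NC(N)=S` gives 22500 nM, while compound 2 `Cc1nn(-c2ccccc2)c(Oc2ccc(-c3nc4cc(C(N)=O)ccc4[nH]3)cc2)c1/C=N/NC(N)=O` gives 9600 nM, the lower of the two numbers by a gap beyond the usual scatter. Compound 3 `Cc1nn(-c2ccccc2)c(Oc2ccc(-c3nc4cc(C(N)=O)ccc4[nH]3)cc2)c1/C=N/NC(N)=S` keeps the core of compound 2 and changes one group on an amine nitrogen: a group of 3 heavy atoms (1 carbon, 1 nitrogen, 1 sulfur; no ring) in place of a group of 3 heavy atoms (1 carbon, 1 nitrogen, 1 oxygen; no ring), on an amine nitrogen. Among the measured compounds shown here, no measured pair isolates this change, so in this assay only a slight shift towards stronger inhibition of growth is expected, probably within the scatter. The estimated step is a 1.2-fold lower number from compound 2 to compound 3 (0.08 log units; within the scatter). For compound 3, the expected value is 8000 nM, with an estimated range of 2500 nM to 25000 nM.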

Compound 3, concentration for 50% growth inhibition: 37500 nM
The estimate for compound 3 lay 4.7-fold (0.67 log units) below the measured number; measured number above the stated range.
By their numbers in this assay, from the lowest: compound 2; then compounds 1 and 3 (each within the scatter of the next).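

Swapping carbamoyl for the sulfur-bearing group on the amine nitrogen gives, in this assay, a 3.9-fold higher number from compound 2 to compound 3 (0.59 log units; beyond the scatter), so at this position the change moves towards weaker inhibition of growth. By contrast, carbamoyl in place of nitro on an aromatic carbon gives a 1.7-fold higher number from compound 1 to compound 3 (0.22 log units; within the scatter), so no effect of that swap can be claimed here. No measurement at hand offers an explanation for either result.

Going by these compounds, whether a methyl or an acetyl group on this amine nitrogen would give stronger or weaker inhibition of growth remains open. So does whether the carbamoyl-to-sulfur step would be the same size in compounds carrying nitro on the aromatic carbon.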